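Changing the aryl group on the ring nitrogen once more

A few compounds are considered here, and "the series" means these few. Any claim that something is new, unique, unknown or untested is made for them only; others in the source may bear on it.

Of the compounds shown here, three built on one shared core have been measured in an assay on isolated protein for inhibition of protein kinase C zeta type (Homo sapiens), with a stated time of 4 min, tested at 62.5 uM; a lower number here means less inhibition, a higher number more inhibition at the concentration tested (going by the name of the read-out). Compound 1 `CC(C)(C)C1=NN(c2ccc(Br)cc2)C(c2ccc(O)cc2)C1` gives 93.2%. Compound 2 `CC(C)(C)C1=NN(c2cccc(Cl)c2)C(c2ccc(O)cc2)C1` gives 96.8%. Compound 3 `Cc1cccc(N2N=C(C(C)(C)C)CC2c2ccc(O)cc2)c1` gives 91.7%. On these numbers compound 3 stands lowest of the three, but both of its gaps to the others lie within the scatter: the step of a number 1.5 percentage points lower from compound 1 to compound 3 (within the scatter) and the step of a number 5.1 percentage points lower from compound 2 to compound 3 (within the scatter) are each too small to count as a real difference, so no ordering among the three can be claimed.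

Compound 4 `CC(C)(C)C1=NN(c2ccccc2F)C(c2ccc(O)cc2)C1` has not yet been measured. It differs from compound 3 in one place: 2-fluorophenyl in place of 3-methylphenyl on an amine nitrogen in a ring. Every measured step in this set is an exchange of the aryl group on that same ring nitrogen, including a number 3.6 percentage points higher from compound 1 to compound 2 (within the scatter), and none of them moved the inhibition beyond the scatter. On that basis the expected step from compound 3 to compound 4 is no change beyond the scatter, a number 1.3 percentage points higher from compound 3 to compound 4 (within the scatter). Compound 4 is therefore estimated to give 93% in this assay, with a range from 80% to 99%.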

Compound 4, a percentage reported as inhibition, at one concentration (the size of the read-out at that concentration, not a potency): 57.6%
Compound 4: middle estimate off by 35.4 percentage points, on the high side; measured number below the stated range.
By their numbers in this assay, from the lowest: compound 4; then compounds 3, 1 and 2 (each within the scatter of the next).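

So the aryl group on this ring nitrogen does not accept every exchange: the earlier swaps among 3-chlorophenyl, 4-bromophenyl and 3-methylphenyl stayed within the scatter, whereas in this assay the change to 2-fluorophenyl gives a number 34.1 percentage points lower from compound 3 to compound 4 (beyond the scatter) as well as a number 39.2 percentage points lower from compound 2 to compound 4 (beyond the scatter) and a number 35.6 percentage points lower from compound 1 to compound 4 (beyond the scatter). All three steps run the same way and all lie beyond the scatter, so among these four compounds only compound 4 stands apart, while the three others form one group that no ordering can divide. The size of the exchanged group does not separate them in any simple way, as 3-methylphenyl and 2-fluorophenyl have the same count of heavy atoms, and nothing given here explains the loss of inhibition.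

Going by these compounds, what stays open is whether the fall goes with the fluorine itself or with the 2-position of the substituent on the phenyl ring, as compound 4 differs from the others in both. A 3-fluorophenyl or a 2-methylphenyl group on the same nitrogen would tell these two readings apart, and an unsubstituted phenyl group would give a reference for both.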